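Butyl Replaces Tert-Butyl on the Hydroxy-Bearing Carbon

The source may hold more compounds than are shown below. What is called first, only, known or untested is meant among the compounds shown, and "the series" means these compounds.

Of the compounds shown here, three sharing one core have been tested in a functional assay on a cell-free system (plasma, Homo sapiens), with a stated time of 3 min; a higher number here means a weaker inhibitor, a lower number a stronger inhibitor. Compound 3 `CC(C)(C)[C@@H](O)C(=O)N1[C@@H]2C[C@@H]2C[C@H]1C(=O)NCc1cc(Cl)ccc1-n1cnnn1` gives 1100 nM. Compound 1 `CC1(C[C@@H](O)C(=O)N2[C@@H]3C[C@@H]3C[C@H]2C(=O)NCc2cc(Cl)ccc2-n2cnnn2)CC1` gives 1300 nM, and compound 2 `O=C(NCc1cc(Cl)ccc1-n1cnnn1)[C@@H]1C[C@H]2C[C@H]2N1C(=O)[C@H](O)c1ccccc1` gives 680 nM. Compound 3 stands second highest of the three numbers: its nearest neighbour is compound 1, with a 1.2-fold lower number from compound 1 to compound 3 (0.07 log units; within the scatter), and the furthest is compound 2, with a 1.6-fold higher number from compound 2 to compound 3 (0.21 log units; within the scatter). The remaining step, a 1.9-fold lower number from compound 1 to compound 2 (0.28 log units; within the scatter), is also within the scatter, so the group on a saturated chain carbon bound to a carbonyl carbon and an oxygen on a saturated carbon has so far moved the numbers little.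

Compound 4 `CCCC[C@@H](O)C(=O)N1[C@@H]2C[C@@H]2C[C@H]1C(=O)NCc1cc(Cl)ccc1-n1cnnn1` differs from compound 3 in one place: butyl in place of tert-butyl on a saturated chain carbon bound to a carbonyl carbon and an oxygen on a saturated carbon. Among the measured compounds shown here, no measured step exchanges tert-butyl for butyl, but all three steps at this position stayed within the scatter. The expected step is therefore a 1.1-fold lower number from compound 3 to compound 4 (0.04 log units; within the scatter), a change of no more than the scatter. The estimate for compound 4 in this assay is 1000 nM, with a range from 400 nM to 2500 nM.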

Compound 4, half-maximal inhibitory concentration: 870 nM
For compound 4 the middle estimate is 1.1-fold (0.06 log units) above the measured one; low and high end bracket the measured number.
By their numbers in this assay, from the lowest: compounds 2, 4, 3 and 1 (each within the scatter of the next).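

Exchanging tert-butyl for butyl, the same four carbons joined differently, gives a 1.3-fold lower number from compound 3 to compound 4 (0.10 log units; within the scatter) in this assay and so stays within the scatter. Butyl also stays within the scatter of the other two groups, with a 1.3-fold higher number from compound 2 to compound 4 (0.11 log units; within the scatter) and a 1.5-fold lower number from compound 1 to compound 4 (0.17 log units; within the scatter) in the same assay. An unbranched chain on a saturated chain carbon bound to a carbonyl carbon and an oxygen on a saturated carbon therefore gives a number that cannot be told apart from those of the tert-butyl, phenyl and (1-methylcyclopropyl)methyl compounds, so all four groups now read alike at this position.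

From the compounds shown here alone, whether an amine, a carboxylic acid or a longer chain at this position would move the number beyond the scatter remains open. Nothing available explains why these four groups read alike.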